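A longer linker between the shared core and the phenyl ring

A few compounds are considered here, and "the series" means these few. Any claim that something is new, unique, unknown or untested is made for them only; others in the source may bear on it.

Three compounds share one core and differ only at the group on a saturated chain carbon bound to a nitrogen on an aromatic ring, or by a fluoro on an aromatic carbon. In a functional assay on cells for positive allosteric modulation of G-protein coupled receptor 68 (Homo sapiens), read by a luciferase reporter and cAMP accumulation, with a stated time of 30 min, at pH 6.8 and pH 8.3, in the presence of a further agent that is not named here (a lower number here means a less potent compound, a higher number a more potent compound, by a factor of ten per unit of this negative logarithm), compound 1 `Cc1cccc(CNc2nc(N)nc(-c3ccccc3CO)n2)c1` gives 4.4, compound 2 `Nc1nc(NCc2ccc(F)cc2)nc(-c2c(F)cccc2CO)n1` gives 4.45, and compound 3 `Cc1cccc(CNc2nc(N)nc(-c3c(F)cccc3CO)n2)c1` gives 4.44. Going by the values given here, compound 3 stands second highest of the three, but the steps of a number 0.04 log units higher from compound 1 to compound 3 (within the scatter) and a number 0.01 log units lower from compound 2 to compound 3 (within the scatter) both lie within the scatter, so no compound can be called more potent than another. Compound 4 `Nc1nc(NCCCCc2ccccc2)nc(-c2c(F)cccc2CO)n1` brings the change (3-phenylpropyl in place of 3-methylphenyl on a saturated chain carbon bound to a nitrogen on an aromatic ring). Among the compounds with values here, only the step from compound 2 to compound 3 touches this position, and it was flat; nothing measured speaks to a longer chain. Compound 4 is therefore expected to sit near compound 3, with an estimated 4.4 spanning 3.9 to 4.9, a step of a number 0.04 log units lower from compound 3 to compound 4 (within the scatter) that is expected to remain within the scatter.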

Compound 4, negative logarithm of the antagonist equilibrium constant: 4.04
Estimate against measurement, compound 4: 0.36 log units above, within the range that was stated.
By their numbers in this assay, from the lowest: compound 4; then compounds 1, 3 and 2 (each within the scatter of the next).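

Going by these compounds alone, the position on a saturated chain carbon bound to a nitrogen on an aromatic ring is not as flat as the earlier compounds suggested. Putting 3-phenylpropyl in place of 3-methylphenyl gives a number 0.40 log units lower from compound 3 to compound 4 (beyond the scatter), and putting it in place of 4-fluorophenyl gives a number 0.41 log units lower from compound 2 to compound 4 (beyond the scatter), so this group can be told apart from both earlier groups. No evidence at hand accounts for this drop. The compounds shown leave open how 2-phenylethyl or a longer chain would read in this assay, and whether an amine at the end of the chain would change the number.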